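The source may report more compounds than this note shows. Statements on the series, on what has been measured and on what is new or still open speak of the compounds shown alone.

In a functional assay on A549 cells (Homo sapiens) for cytotoxicity, read by MTT assay (on this read-out higher numbers stand for weaker inhibition and lower numbers for stronger inhibition), compound 1 (`COC(=O)C[C@@H]1C[C@@H](O)[C@H](C)[C@H](c2ccccc2)N1`) gives 8500 nM, compound 2 (`COC(=O)C[C@H]1C[C@@H](O)[C@@H](C)[C@@H](c2ccc(F)cc2)N1`) gives 26600 nM and compound 3 (`COC(=O)C[C@H]1C[C@@H](O)[C@H](C)[C@@H](c2ccccc2)N1`) gives 34600 nM. Compound 3 thus lies within the scatter of compound 2 and on the clearly weaker side of compound 1. Compound 4 (`COC(=O)C[C@H]1C[C@H](O)[C@H](C)[C@@H](c2ccccc2)N1`) departs from compound 3 by the two compounds have the same atoms and bonds and differ only in configuration as drawn: 1 of 4 stereo elements differ; a stereocentre at a saturated ring carbon is drawn R in compound 3 and S in compound 4. Among the measured compounds shown here, the one measured step that bears on this is a 4.1-fold higher number from compound 1 to compound 3 (0.61 log units; beyond the scatter), a shift traced to the fact that compounds 1 and 3 differ only in the configuration as drawn, and it involved 2 of 4 stereo elements rather than 1. A similar or smaller step is therefore expected in this assay, with a slight lean towards lower numbers, since compound 3 stands at 34600 nM. The estimated step is a 1.6-fold lower number from compound 3 to compound 4 (0.20 log units; within the scatter). For compound 4 the expected value is 22000 nM, with an estimated range of 9000 nM to 55000 nM.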

Compound 4, half-maximal inhibitory concentration: 69200 nM
Compound 4: the middle estimate sits 3.1-fold (0.50 log units) below what was measured; the measured number lies above the stated range.
By their numbers in this assay, from the lowest: compound 1; then compounds 2, 3 and 4 (each within the scatter of the next, the first and the last beyond it).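

Changing this single stereocentre at a saturated ring carbon gives a 2.0-fold higher number from compound 3 to compound 4 (0.30 log units; within the scatter), so in this assay this one change alone does not separate the two compounds beyond the scatter. Changing three stereo elements gives an 8.1-fold higher number from compound 1 to compound 4 (0.91 log units; beyond the scatter), which is beyond the scatter and is the widest gap among compound 1, compound 3 and compound 4: the fact that compounds 1 and 4 differ only in the configuration as drawn

On these data alone, what each of the other stereocentres contributes on its own remains open. As far as these compounds go, it is also open whether a carboxylic acid in place of the ester on the shared core would preserve this order.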